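A phenyl amide in place of a fluoropyridyl amide

The source may report more compounds than this note shows. Statements on the series, on what has been measured and on what is new or still open speak of the compounds shown alone.

compound 1 `O=C(COc1ccc2cc(/C=C3/SC(=O)NC3=O)ccc2c1)Nc1ccc(Br)cc1F`: > 50000 nM (a limit)
compound 2 `O=C(COc1ccc2cc(/C=C3/SC(=O)NC3=O)ccc2c1)Nc1cccc(F)n1`: 7200 nM
compound 3 `O=C(COc1ccc2cc(/C=C3/SC(=O)NC3=O)ccc2c1)Nc1ccc(F)cc1F`: > 50000 nM (a limit)

In an assay on isolated protein for inhibition of histone deacetylase 8 (Homo sapiens), with a stated time of 1 h (a lower number here means a stronger inhibitor, a higher number a weaker inhibitor), compound 1 reaches only the limit > 50000 nM. Compound 3 likewise sits at the limit > 50000 nM. Within the data shown here, compound 2 gives 7200 nM, the only number among the three measured compounds. Both measured steps that bear on the move to compound 4 start or end at that number: an at least 6.9-fold lower number from compound 1 to compound 2 (0.84 log units; beyond the scatter) and an at least 6.9-fold higher number from compound 2 to compound 3 (0.84 log units; beyond the scatter). Among the measured compounds shown here, in each, the compound carrying a phenyl-type amide is the one that gives no number, as the limit of > 50000 nM in this assay, at which 2 of the 3 values shown sit, shows. Compound 4 `O=C(COc1ccc2cc(/C=C3/SC(=O)NC3=O)ccc2c1)Nc1ccc(F)cc1` differs from compound 2 in the same place: 4-fluorophenyl in place of 6-fluoropyridin-2-yl on an amide-type nitrogen. Compound 4 is therefore expected to give a much higher number, with an expected step of a 5.6-fold higher number from compound 2 to compound 4 (0.74 log units; beyond the scatter). The estimate for compound 4 in this assay is 40000 nM, expected between 10000 nM and 150000 nM, with a real chance that only a limit is reported.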

Compound 4, half-maximal inhibitory concentration: 6600 nM
Beside the measured number, compound 4's estimate is 6.1-fold (0.78 log units) above it, and the stated range ends above it.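

In this assay, the result shows that a carbon-only ring on the amide-type nitrogen does not by itself cost the measurable activity: a 1.1-fold lower number from compound 2 to compound 4 (0.04 log units; within the scatter). The drop seen earlier therefore tracks with the further substitution on the phenyl ring, since removing one fluoro gives an at least 7.5-fold lower number from compound 3 to compound 4 (0.87 log units; beyond the scatter), and the wider change from 4-bromo-2-fluorophenyl gives an at least 7.5-fold lower number from compound 1 to compound 4 (0.87 log units; beyond the scatter). As far as these compounds go, compound 1 and compound 3 give only an assay limit, not a number, so the true size of both steps stays unknown: the limit of > 50000 nM in this assay, at which 2 of the 4 values shown sit.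

The compounds shown leave open whether any added group on that ring would have the same effect, or only fluoro and bromo, as a methyl or methoxy group might show. They also leave open how much the fluoro of 4-fluorophenyl contributes, which an unsubstituted phenyl amide would test.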